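The source may hold more compounds than are shown below. What is called first, only, known or untested is meant among the compounds shown, and "the series" means these compounds.

Compound 1 `Fc1ccc2c([C@@H]3CNCC[C@H]3F)c(-c3ccsc3)[nH]c2c1` gives 2.8 nM in an assay for binding affinity to Adrenergic receptor alpha-1 (Rattus norvegicus); a lower number here means a stronger inhibitor, a higher number a weaker inhibitor.
Compound 2 `Fc1ccc2c([C@@H]3CNCC[C@H]3F)c(-c3ccc4ccccc4c3)[nH]c2c1` gives 2.1 nM in this assay.

Compound 1 has the higher of these two numbers, but compound 2 sits within the usual scatter of it, so the two cannot be set in order. Compound 3 `Fc1ccc2c([C@@H]3CNCC[C@H]3F)c(-c3ccoc3)[nH]c2c1` differs from compound 1 in one place: furan-3-yl in place of thiophen-3-yl on an aromatic carbon. Within the data shown here, no measured pair shows this exchange, so no step size can be read from the data. The two groups are alike in size and in what they count, so only a small step is expected, if any, perhaps a slight weakening. For compound 3 the estimate is 4.5 nM, in the range 1.5 nM to 14 nM, a step from compound 1 to compound 3 of a 1.6-fold higher number from compound 1 to compound 3 (0.21 log units; within the scatter).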

Compound 3, inhibition constant: 3.6 nM
The estimate for compound 3 lay 1.3-fold (0.10 log units) above the measured number; low and high end bracket the measured number.
By their numbers in this assay, from the lowest: compounds 2, 1 and 3 (each within the scatter of the next).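

Putting furan-3-yl in place of thiophen-3-yl gives a 1.3-fold higher number from compound 1 to compound 3 (0.11 log units; within the scatter) in this assay, so on this aromatic carbon, oxygen can stand where sulfur stood in the five-membered ring with no difference that can be read. Among these compounds, this is the first exchange at this position whose step can be read, and it is a close one between two groups of equal size. Nothing shown explains why the two rings give such similar numbers.

Going by these compounds, it stays open whether a group with a ring nitrogen, such as pyridin-3-yl, would fit this pattern. The same holds for a non-aromatic group, such as a butyl chain or a carboxylic acid.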